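Aryl sulfone variation on the shared core

This account rests on a few compounds, and the source may have more. Where it says the series, first, only, none or still open, it means among the compounds named here.

Measured so far:
compound 1, `CN1CCC(n2cc(S(=O)(=O)c3cccc(F)c3)c3cccnc32)C1`: 1.4 nM in an assay on HeLa cells for displacement of a labelled ligand from 5-hydroxytryptamine receptor 6 (Homo sapiens); a lower number here means a stronger inhibitor, a higher number a weaker inhibitor
compound 2, `CN1CCCC(n2cc(S(=O)(=O)c3cccc(C(F)(F)F)c3)c3cccnc32)C1`: 2.1 nM
compound 3, `CN1CCCC(n2cc(S(=O)(=O)c3cccc(F)c3)c3cccnc32)C1`: 4.7 nM

Compound 3 gives the highest number of the three in this assay. Its nearest neighbour is compound 2, reached by the step of a 2.2-fold higher number from compound 2 to compound 3 (0.35 log units; beyond the scatter); the furthest is compound 1, reached by a 3.4-fold higher number from compound 1 to compound 3 (0.53 log units; beyond the scatter). Both steps lie beyond the scatter, though each is modest in size.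

Compound 4, `CN1CCCC(n2cc(S(=O)(=O)c3cc(Cl)cc(Cl)c3)c3cccnc32)C1`, has not been measured. It differs from compound 3 at one place only: 3,5-dichlorophenyl in place of 3-fluorophenyl on a sulfonyl sulfur.

For the measured compounds named here, no measured step replaces the aryl ring on the sulfonyl sulfur in this way. Going by the values given here, the only measured step at that ring, a 2.2-fold higher number from compound 2 to compound 3 (0.35 log units; beyond the scatter), shows that exchanging a single substituent there moves the number by a modest amount in this assay, with the fluoro compound giving the higher number. The step of a 3.4-fold higher number from compound 1 to compound 3 (0.53 log units; beyond the scatter) concerns the ring on the aromatic nitrogen and does not bear on the change. Among the compounds with values here, a modest step is therefore expected, most likely towards a lower number than that of compound 3, though no measured step fixes the direction for two chloro groups.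

Compound 4 is estimated at 3 nM, with a range of 1.2 nM to 8 nM. This estimate means an expected step of a 1.6-fold lower number from compound 3 to compound 4 (0.19 log units; within the scatter).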

Compound 4, inhibition constant: 3.9 nM
The estimate for compound 4 lay 1.3-fold (0.11 log units) below the measured number; low and high end bracket the measured number.
By their numbers in this assay, from the lowest: compounds 1, 2, 4 and 3 (each within the scatter of the next, the first and the last beyond it).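

Exchanging 3-fluorophenyl for 3,5-dichlorophenyl on the sulfonyl sulfur gives, in this assay, a 1.2-fold lower number from compound 3 to compound 4 (0.08 log units; within the scatter) and so leaves the number unchanged within the scatter. The earlier compounds shown here showed only the exchange of one substituent for another at this ring, a 2.2-fold higher number from compound 2 to compound 3 (0.35 log units; beyond the scatter), a modest step beyond the scatter; the new result adds that a ring with two chloro groups is accepted at this position, with compound 4 at 3.9 nM and compound 2 at 2.1 nM lying within the scatter of each other. Nothing available explains why the number holds across this exchange.

The compounds shown carry only fluoro, trifluoromethyl or chloro on this ring, which leaves open how the number responds to a group of another kind there, such as an amine, a carboxylic acid or a methoxy group. As far as these compounds go, it also remains open whether 3,5-dichlorophenyl on the sulfonyl sulfur gives a similar result when 1-methylpyrrolidin-3-yl, as in compound 1, stands on the aromatic nitrogen.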